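This account rests on a few compounds, and the source may have more. Where it says the series, first, only, none or still open, it means among the compounds named here.

Compound 1 `COc1ccc(C(=O)N2N=C(c3ccccc3)CC2c2cn(C)c3ccccc23)cn1`: 4310 nM
Compound 2 `Cc1ccc(C(=O)N2N=C(c3ccccc3)CC2c2cn(C)c3ccccc23)cn1`: 4010 nM
Compound 3 `COc1cccc(C2=NN(C(=O)c3ccc(C)nc3)C(c3cn(C)c4ccc(OC)cc34)C2)c1`: 90 nM

In a functional assay on MCF7 cells (Homo sapiens) for inhibition, read by MTT assay, with a stated time of 48 h (a lower number here means a stronger inhibitor of growth, a higher number a weaker inhibitor of growth), compound 2 gives 4010 nM and compound 1 gives 4310 nM. The two differ by methoxy in place of methyl on an aromatic carbon, and the step is a 1.1-fold higher number from compound 2 to compound 1 (0.03 log units; within the scatter), which is within the scatter. Compound 3 gives 90 nM; the difference between its core and the core of compound 2 is not broken down here, and the two values simply show that compound 3 sits far lower. Compound 4 `COc1cccc(C2=NN(C(=O)c3ccc(OC)nc3)C(c3cn(C)c4ccc(OC)cc34)C2)c1` is not yet measured. It differs from compound 3 by methoxy in place of methyl on an aromatic carbon, the same change already seen between compound 2 and compound 1. Because that earlier step was a 1.1-fold higher number from compound 2 to compound 1 (0.03 log units; within the scatter), compound 4 is expected to stay close to compound 3, with an estimated step of a 1.1-fold higher number from compound 3 to compound 4 (0.05 log units; within the scatter). The estimate for compound 4 is 100 nM, expected between 45 nM and 220 nM.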

Compound 4, concentration for 50% growth inhibition: 130 nM
Beside the measured number, compound 4's estimate is 1.3-fold (0.11 log units) below it; the range from low to high includes it.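

In this assay, the change from 6-methylpyridin-3-yl to 6-methoxypyridin-3-yl gives a 1.4-fold higher number from compound 3 to compound 4 (0.16 log units; within the scatter). Set beside the earlier step, the change carries from one core to the other with no difference that can be read: the same change on two cores in this assay, a 1.1-fold higher number (0.03 log units; within the scatter) from compound 2 to compound 1 and a 1.4-fold higher number (0.16 log units; within the scatter) from compound 3 to compound 4, 1.3-fold (0.13 log units) apart, within the scatter of two such steps This shows that the swap of methyl for methoxy made no readable difference on either of these two cores, but with only two pairs it does not show that the same would hold on any other core in the series.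

The compounds shown leave open how an amine, a carboxylic acid or a longer chain such as ethoxy would read at this place in this assay. They also leave open which of the differences between the core of compound 2 and the core of compound 3 goes with the gap in their values.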